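This account rests on a few compounds, and the source may have more. Where it says the series, first, only, none or still open, it means among the compounds named here.

The account concerns two compounds measured in a functional assay on COLO 205 cells (Homo sapiens) for cytotoxicity, read by sulforhodamine B assay, with a stated time of 48 h (on this read-out higher numbers stand for lower toxicity in this test and lower numbers for higher toxicity in this test), and compound 3, which has not yet been tested there. Compound 1, with the structure `ClCc1ccccc1Cn1cnc2c(Cl)ncnc21`, does not reach a measurable value: in this assay compound 1 gives > 100000 nM, which is a limit of the assay and not a number. Compound 2, with the structure `ClCc1ccccc1Cn1cnc2ncnc(Cl)c21`, stands in the same place; in this assay compound 2 gives > 100000 nM, again a limit rather than a measured number. Within the data shown here, both values therefore sit at the limit of > 100000 nM in this assay, at which 2 of the 2 values shown sit, and no step between measured compounds can be drawn from them.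

Compound 3, with the structure `ClCc1ccccc1Cn1cnc2nc(Cl)nc(Cl)c21`, differs from compound 2 by chloro in place of hydrogen on an aromatic carbon, on the carbon between two ring nitrogen atoms of the six-membered ring. With nothing but limits behind it, compound 3 is expected to sit at the same limit, so the step of a number no higher from compound 2 to compound 3 (the limit leaves the size open) is estimated as none beyond the scatter. Compound 3 is thus estimated at 100000 nM, within a range of 30000 nM to 300000 nM.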

Compound 3, concentration lethal to 50% of the cells: > 100000 nM
Compound 3 gave a limit, no number (the forecaster's own chance of this, stated with the estimate: 80%); the middle value lies on the limit itself.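

In this assay compound 3 gives > 100000 nM, a limit of the assay and not a number. No step can be read between compound 2 and compound 3, which both end at the limit: the limit of > 100000 nM in this assay, at which 3 of the 3 values shown sit.

The compounds shown leave open whether chloro in place of hydrogen on that aromatic carbon changes the toxicity at all, and how the three compounds rank against one another.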